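This account rests on a few compounds, and the source may have more. Where it says the series, first, only, none or still open, it means among the compounds named here.

Compound 1 `CCCCC1NC(=O)NC(C)=C1C(=O)OC` gives 78200 nM in an assay for inhibition of beta-glucuronidase (Bos taurus), read by spectrophotometry, with a stated time of 30 min; a lower number here means a stronger inhibitor, a higher number a weaker inhibitor. Compound 2 `COC(=O)C1=C(C)NC(=O)NC1CC(C)C` gives 55200 nM in this assay. Compound 3 `COC(=O)C1=C(C)NC(=O)NC1c1ccc(C)o1` gives 44200 nM in this assay.

Compound 3 has the lowest of the three numbers, yet its gaps to the others are small: a 1.2-fold lower number from compound 2 to compound 3 (0.10 log units; within the scatter) and a 1.8-fold lower number from compound 1 to compound 3 (0.25 log units; within the scatter), so no ranking can be drawn. Compound 4 `COC(=O)C1=C(C)NC(=O)NC1c1cccs1` arises from compound 3 by a change of the ring hanging off the core: thiophen-2-yl in place of 5-methylfuran-2-yl on a saturated ring carbon. The two steps that bear on this position, a 1.8-fold lower number from compound 1 to compound 3 (0.25 log units; within the scatter) and a 1.2-fold lower number from compound 2 to compound 3 (0.10 log units; within the scatter), swapped a chain for the furan ring and stayed within the scatter. Going by the values given here, no measured step exchanges one aromatic ring for another. A change within the scatter is therefore expected, a 1.1-fold lower number from compound 3 to compound 4 (0.02 log units; within the scatter), so compound 4 is estimated at 42000 nM, between 15000 nM and 110000 nM.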

Compound 4, half-maximal inhibitory concentration: 18200 nM
Estimate against measurement, compound 4: 2.3-fold (0.36 log units) above; low and high end bracket the measured number.
By their numbers in this assay, from the lowest: compound 4; then compounds 3, 2 and 1 (each within the scatter of the next).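

In this assay, the group on this saturated ring carbon now matters beyond the scatter: exchanging one aromatic ring for another gives a real step (a 2.4-fold lower number from compound 3 to compound 4 (0.39 log units; beyond the scatter)). Thiophen-2-yl also separates from both chains (a 3.0-fold lower number from compound 2 to compound 4 (0.48 log units; beyond the scatter); a 4.3-fold lower number from compound 1 to compound 4 (0.63 log units; beyond the scatter)), which 5-methylfuran-2-yl did not do. Nothing available here explains the difference between the two rings.

This swap exchanges oxygen for sulfur and removes the methyl at the same time, and the compounds shown leave open which of the two changes matters. Plain furan-2-yl would separate them, and phenyl would test a six-membered aromatic ring here.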